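A Methyl at the Oxygen-Bearing Chain Carbon

A few compounds are considered here, and "the series" means these few. Any claim that something is new, unique, unknown or untested is made for them only; others in the source may bear on it.

Of the compounds shown here, two have so far been measured in an assay on HEK293 cells for agonist activity at probable G-protein coupled receptor 34 (Mus musculus), with a stated time of 1 h; on this read-out higher numbers stand for larger maximal responses and lower numbers for smaller maximal responses. Compound 1 `CCCCCCCC/C=C\CCCCCCCC(=O)OC[C@@H](COCCC)OP(=O)(O)OC[C@H](N)C(=O)O` gives 12.2% in this assay, a small maximal response. Compound 2 `N[C@@H](COP(=O)(O)OCCOC(=O)CCc1ccccc1OCc1cccc(Oc2ccccc2)c1)C(=O)O` gives 12.4% in this assay. The number for compound 2 is the higher of the two, yet its gap to compound 1 lies within the scatter, so the two compounds read as alike on this read-out.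

Compound 3 `C[C@H](COP(=O)(O)OC[C@H](N)C(=O)O)OC(=O)CCc1ccccc1OCc1cccc(Oc2ccccc2)c1` has not yet been measured. It differs from compound 2 in one place: methyl in place of hydrogen on a saturated chain carbon bound to an oxygen next to a carbonyl group and a saturated chain carbon.

Among the measured compounds shown here, no step between measured compounds is available to guide the expectation, and both measured numbers sit low and close together. The estimated step is therefore a number 1.6 percentage points higher from compound 2 to compound 3 (within the scatter), which is expected to stay within the scatter. Compound 3 is expected to reach 14% in this assay, within a range from 5% to 32%.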

Compound 3, largest response reached (Emax), in percent of the reference or control that the assay uses: 12%
For compound 3 the middle estimate is 2 percentage points above the measured one; measured number inside the range.
By their numbers in this assay, from the lowest: compounds 3, 1 and 2 (each within the scatter of the next).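

In this assay, methyl in place of hydrogen on a saturated chain carbon bound to an oxygen next to a carbonyl group and a saturated chain carbon gives a number 0.4 percentage points lower from compound 2 to compound 3 (within the scatter). Among the compounds shown here, this is the first single-place comparison, and it shows that this position accepts the added methyl with no change beyond the scatter on this read-out. No other measurement bears on this result.

From the compounds shown here alone, whether an ethyl group, a longer chain or a hydroxyl group at this carbon would leave the maximal response equally unchanged stays open, as does the effect of the opposite spatial arrangement of the methyl. Going by these compounds, since compound 2 and compound 3 both give small maximal responses, it also stays open whether the methyl would be accepted as well in a compound with a large maximal response.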